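The source may hold more compounds than are shown below. What is called first, only, known or untested is meant among the compounds shown, and "the series" means these compounds.

Measured compounds:
- compound 1 `O=C(c1sc(-c2cccc(F)c2)nc1O)N1CCCOC1` gives > 100000 nM in an assay on HEK293 cells for inhibition of transient receptor potential cation channel subfamily M member 8 (Homo sapiens), read by FLIPR, with stated times of 5 min and 3 min; on this read-out higher numbers stand for weaker inhibition and lower numbers for stronger inhibition
- compound 2 `CCOC(=O)c1oc(-c2ccc(Cl)cc2)nc1O` gives > 100000 nM
- compound 3 `CCn1nnc(-c2sc(-c3c(Cl)cccc3Cl)nc2O)n1` gives 16500 nM

Compound 1 sits at the limit of > 100000 nM in this assay, at which 2 of the 3 values shown sit, which is a limit of the assay rather than a measured number: it shows only that no inhibition was reached within the tested range. Compound 2 sits at the same limit. Compound 3 is the only one of the three with a measured number, and its value shows weaker inhibition than would count as potent in this setting.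

Compound 4 `O=C(c1sc(-c2cccc(F)c2)nc1O)N1CCCCCO1` has not yet been tested. It differs from compound 1 in one place: a group of 7 heavy atoms (5 carbon, 1 nitrogen, 1 oxygen; one seven-membered non-aromatic ring with 2 hetero atoms) in place of a group of 6 heavy atoms (4 carbon, 1 nitrogen, 1 oxygen; one six-membered non-aromatic ring with 2 hetero atoms), on a carbonyl carbon. Within the data shown here, no measured pair that differs in one place is available to judge the size of such a step.

Since compound 1 gives > 100000 nM, a limit, the expected step of a number no higher from compound 1 to compound 4 (the limit leaves the size open) is none beyond the scatter, and compound 4 is estimated at 100000 nM, between 30000 nM and 300000 nM, most likely again reported only as a limit.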

Compound 4, half-maximal inhibitory concentration: 32 nM
The estimate for compound 4 lay 3100-fold (3.49 log units) above the measured number, and the stated range ends above it.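

In this assay, putting the seven-membered non-aromatic ring with 2 hetero atoms in place of the six-membered one, on a carbonyl carbon, gives an at least 3100-fold lower number from compound 1 to compound 4 (3.49 log units; beyond the scatter). This is the first pair shown that differs in one place, and it reveals that the group on this carbonyl carbon can alone separate a compound with no measured inhibition from one with strong inhibition, although the group only goes from 6 heavy atoms to 7 and its hydrogen-bond donor and acceptor counts stay the same. The full size of the step remains unknown, since the value of compound 1 is a limit of the assay and not a number: the limit of > 100000 nM in this assay, at which 2 of the 4 values shown sit.

The two rings differ both in size and in how their nitrogen and oxygen are arranged, so this pair cannot say which of the two matters; azepane, a seven-membered ring with nitrogen as its only hetero atom, would help to separate them. Going by these compounds, it also remains open whether a larger ring, such as an eight-membered ring holding nitrogen and oxygen, or an open chain such as a diethylamide would be tolerated on this carbonyl carbon.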